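A few compounds are considered here, and "the series" means these few. Any claim that something is new, unique, unknown or untested is made for them only; others in the source may bear on it.

Working notes on the series. Compound 1 `Cc1cc(C#N)cc(C)c1Oc1nc(Nc2ccc(C#N)cc2)ncc1/C=C/C(=O)NC1CC1` is assessed in an ADME assay on TZM cells (Homo sapiens) for cytotoxicity, with a stated time of 1 days; on this read-out lower numbers stand for higher toxicity in this test and higher numbers for lower toxicity in this test. In this assay compound 1 gives only a limit, > 221 nM. Compound 2 `Cc1cc(C#N)cc(C)c1Oc1nc(Nc2ccc(C#N)cc2)ncc1/C=C/C(=O)NCC1CCN(S(C)(=O)=O)C1` also gives a limit in this assay, > 175 nM. Compound 3 `Cc1cc(C#N)cc(C)c1Oc1nc(Nc2ccc(C#N)cc2)ncc1/C=C/C(=O)N1CCN(S(C)(=O)=O)CC1` likewise gives a limit in this assay, > 179 nM. The steps a step that the two limits leave unreadable from compound 1 to compound 2, a step that the two limits leave unreadable from compound 1 to compound 3 and a step that the two limits leave unreadable from compound 2 to compound 3 are therefore unreadable; (the limit of > 175 nM in this assay, at which 1 of the 3 values shown sits), the limit of > 179 nM in this assay, at which 1 of the 3 values shown sits, and the limit of > 221 nM in this assay, at which 1 of the 3 values shown sits, show that each of the three values sits at a limit rather than at a number. Compound 4 `CC(=O)N1CCN(C(=O)/C=C/c2cnc(Nc3ccc(C#N)cc3)nc2Oc2c(C)cc(C#N)cc2C)CC1` differs from compound 1 by 4-acetylpiperazin-1-yl in place of cyclopropylamino on a carbonyl carbon. Within the data shown here, no measured step bears readably on this change, so no step beyond the scatter in this assay is expected in either direction. Compound 4 is expected to give a limit again, estimated at 220 nM (range 150 nM to 600 nM). The expected step is a number no higher from compound 1 to compound 4 (the limit leaves the size open), nominal only.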

Compound 4, half-maximal cytotoxic concentration: > 192 nM
Compound 4: no number, only a limit; the forecaster's own chance of this, stated with the estimate: 85%; the middle value does not contradict the limit.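

Compound 4, like compound 1, compound 2 and compound 3, gives only a limit in this assay, so no step among these compounds can be read. The compounds shown leave open where any actual cytotoxic concentration lies and whether the group on the carbonyl carbon alters it.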